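Swapping the aryl substituent in a cinnamic acid series

The source may hold more compounds than are shown below. What is called first, only, known or untested is meant among the compounds shown, and "the series" means these compounds.

Measured compounds:
Compound 1, `CC/C(=C(/c1ccc(/C=C/C(=O)O)cc1)c1cc2ccccc2[nH]1)c1ccccc1C`, 33 nM
Compound 2, `CC/C(=C(/c1ccc(/C=C/C(=O)O)cc1)c1cc2ccccc2[nH]1)c1ccccc1C#N`, 9 nM
Compound 3, `CC/C(=C(/c1ccc(/C=C/C(=O)O)cc1)c1cc2ccccc2[nH]1)c1ccccc1C(F)(F)F`, 8 nM

These three compounds share one core and differ only in the substituent on the pendant phenyl ring. In a functional assay on MCF7 cells (Homo sapiens) for inhibition (a lower number here means a stronger inhibitor, a higher number a weaker inhibitor), compound 3 gives the lowest of the three numbers; compound 2 sits within the scatter of it, while compound 1 lies clearly higher, as the step of a 4.1-fold lower number from compound 1 to compound 3 (0.62 log units; beyond the scatter) shows. Compound 4, `CC/C(=C(/c1ccc(/C=C/C(=O)O)cc1)c1cc2ccccc2[nH]1)c1cccc(C)c1`, has not been measured. It differs from compound 3 by 3-methylphenyl in place of 2-(trifluoromethyl)phenyl on a double-bonded chain carbon bound to a double-bonded chain carbon and a saturated chain carbon.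

Going by the values given here, no measured step covers exactly this change, since no measured compound carries a 3-methylphenyl. The steps that come closest are a 3.7-fold lower number from compound 1 to compound 2 (0.56 log units; beyond the scatter) and a 4.1-fold lower number from compound 1 to compound 3 (0.62 log units; beyond the scatter), which show that exchanging a methyl on an aromatic carbon for cyano or trifluoromethyl lowered the number modestly. Returning to a methyl, though not in the same arrangement as in compound 1, is therefore expected to reverse part of that gain: the step of a 3.8-fold higher number from compound 3 to compound 4 (0.57 log units; beyond the scatter) is expected, in the direction of a higher number. Compound 4 is estimated at 30 nM, with a likely range from 10 nM to 100 nM.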

Compound 4, half-maximal inhibitory concentration: 140 nM
Compound 4: the middle estimate sits 4.7-fold (0.67 log units) below what was measured; measured number above the stated range.
By their numbers in this assay, from the lowest: compounds 3 and 2 (each within the scatter of the next); then compound 1; then compound 4.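

Exchanging 2-methylphenyl for 3-methylphenyl gives a 4.2-fold higher number from compound 1 to compound 4 (0.63 log units; beyond the scatter) in this assay and adds no atoms, so this position responds to how the aryl group is arranged and not only to which substituent it carries. Going by these compounds alone, the larger steps, an 18-fold higher number from compound 3 to compound 4 (1.24 log units; beyond the scatter) and a 16-fold higher number from compound 2 to compound 4 (1.19 log units; beyond the scatter), place 3-methylphenyl far behind both 2-(trifluoromethyl)phenyl and 2-cyanophenyl, a gap that the earlier compounds could not reveal. Nothing available here explains why the arrangement matters this much.

The compounds shown leave open whether 3-(trifluoromethyl)phenyl or 3-cyanophenyl would suffer a similar loss, which would show whether the penalty belongs to the arrangement generally or to the methyl alone. They also leave open how an unsubstituted phenyl, or a phenyl bearing an amine or a methoxy group, would compare at this position.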